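Butylamide in Place of the Methyl Ester on the Side Chain

The compounds below may be only part of what the source reports. "The series", "measured", "known", "first", "only" and "open" are said of these compounds alone.

Measured so far:
- compound 1, `CC(C)(N)C(=O)N[C@H](COCc1ccccc1)c1nnnn1Cc1ccc(NS(C)(=O)=O)cc1`: > 5000 nM
- compound 2, `CC(C)(N)C(=O)N[C@H](COCc1ccccc1)c1nnnn1CCCc1ccccc1`: 200 nM
- compound 3, `COC(=O)CCCn1nnnc1[C@@H](COCc1ccccc1)NC(=O)C(C)(C)N`: 2380 nM

In an assay on isolated protein for displacement of a labelled ligand from growth hormone secretagogue receptor type 1 (Homo sapiens), with a stated time of 1 h (on this read-out lower numbers stand for stronger inhibition and higher numbers for weaker inhibition), compound 3 gives 2380 nM, the highest of the two numbers shown. Compound 2 gives 200 nM, and the step of a 12-fold higher number from compound 2 to compound 3 (1.08 log units; beyond the scatter) sets the gap between them. For compound 1 the assay reports only a limit, > 5000 nM (the limit of > 5000 nM in this assay, at which 1 of the 3 values shown sits). The two steps that leave compound 1, an at least 25-fold lower number from compound 1 to compound 2 (1.39 log units; beyond the scatter) and an at least 2.1-fold lower number from compound 1 to compound 3 (0.32 log units; beyond the scatter), are both beyond the scatter.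

Compound 4, `CCCCNC(=O)CCCn1nnnc1[C@@H](COCc1ccccc1)NC(=O)C(C)(C)N`, differs from compound 3 by butylamino in place of methoxy on a carbonyl carbon. Among the measured compounds shown here, no measured step changes this carbonyl carbon, so none bears on it directly; the step of a 12-fold higher number from compound 2 to compound 3 (1.08 log units; beyond the scatter) only shows that this side chain is sensitive to what sits at its end. Compound 4 is therefore expected to give 1200 nM, somewhere between 400 nM and 4000 nM, which means an estimated step of a 2.0-fold lower number from compound 3 to compound 4 (0.30 log units; within the scatter).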

Compound 4, inhibition constant: 1780 nM
For compound 4 the middle estimate is 1.5-fold (0.17 log units) below the measured one; measured number inside the range.
By their numbers in this assay, from the lowest: compound 2; then compounds 4 and 3 (each within the scatter of the next). At a limit, above all of these: compound 1.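

Earlier compounds showed only that replacing the phenyl at the end of this side chain matters; compound 4 shows that the carbonyl end itself can go from methoxy to butylamino, from ester to amide, with no change beyond the scatter: a 1.3-fold lower number from compound 3 to compound 4 (0.13 log units; within the scatter). The amide does not recover what the phenyl of compound 2 gives, leaving an 8.9-fold higher number from compound 2 to compound 4 (0.95 log units; beyond the scatter). Compared with compound 1, the size of the shift is only a minimum, an at least 2.8-fold lower number from compound 1 to compound 4 (0.44 log units; beyond the scatter), because that compound is known only as a limit: the limit of > 5000 nM in this assay, at which 1 of the 4 values shown sits.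

As far as these compounds go, it remains open whether a carboxylic acid at this carbonyl carbon, or benzylamino in place of butylamino, would stay level with compounds 3 and 4 or come closer to compound 2. Methylamino would help separate what the amide hydrogen contributes from what the butyl chain contributes.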